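The source may hold more compounds than are shown below. What is called first, only, known or untested is meant among the compounds shown, and "the series" means these compounds.

Measured so far in an ADME assay on microsomes from liver (Rattus norvegicus) for metabolic stability; on this read-out higher numbers stand for fast clearance and lower numbers for slow clearance:
- compound 1, `CC(C)Oc1cc(Oc2ccc(S(C)(=O)=O)cc2)cc(-c2nccc(=O)[nH]2)c1`: 105 mL/min/kg
- compound 2, `Cc1cnc(-c2cc(Oc3ccc(S(C)(=O)=O)cc3)cc(OC(C)C)c2)[nH]c1=O`: 189 mL/min/kg
- compound 3, `CC(C)Oc1cc(Oc2cnc(C(=O)N(C)C)nc2)cc(-c2nccc(=O)[nH]2)c1`: a limit, < 25.4 mL/min/kg

Compound 1 and compound 2 share one core and differ only by methyl in place of hydrogen on an aromatic carbon. On that pair this assay gives a 1.8-fold higher number from compound 1 to compound 2 (0.26 log units; within the scatter). For compound 3 this assay reports a limit rather than a number, < 25.4 mL/min/kg, and compound 3 sits at the limit of < 25.4 mL/min/kg in this assay, at which 1 of the 3 values shown sits. How the core of compound 3 differs from the core of compound 1 is not broken down here.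

Compound 4, `Cc1cnc(-c2cc(Oc3cnc(C(=O)N(C)C)nc3)cc(OC(C)C)c2)[nH]c1=O`, is not yet measured. It differs from compound 3 by methyl in place of hydrogen on an aromatic carbon, the same change as from compound 1 to compound 2. Among the compounds with values here, on the one measured pair the step stayed within scatter, so a step of about the same size is expected here, a step that the limit leaves unreadable from compound 3 to compound 4, resting on a 1.8-fold higher number from compound 1 to compound 2 (0.26 log units; within the scatter). Since compound 3 is itself at a limit, compound 4 is estimated in this assay at 25 mL/min/kg, between 10 mL/min/kg and 55 mL/min/kg, and may again come back only as a limit.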

Compound 4, clearance in the Rattus norvegicus assay: < 25.4 mL/min/kg
Compound 4: no number, only a limit; the forecaster's own chance of this, stated with the estimate: 50%; the middle value does not contradict the limit.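

In the Rattus norvegicus assay compound 3 gives < 25.4 mL/min/kg as a limit.
In the Rattus norvegicus assay compound 4 gives < 25.4 mL/min/kg as a limit too.
So between compound 3 and compound 4 no step can be read: the limit of < 25.4 mL/min/kg in the Rattus norvegicus assay, at which 2 of the 4 values shown sit.
From the compounds shown here alone, whether methyl in place of hydrogen on an aromatic carbon shifts clearance on the core of compound 3 stays open.
In a physicochemical assay for solubility, in phosphate buffer, measured as kinetic solubility, with a stated time of 24 h, at pH 6.5 (on this read-out higher numbers stand for higher solubility and lower numbers for lower solubility), compound 3 gives 332000 nM and compound 4 gives 218000 nM as measured numbers.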